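Three ethers on a shared core, and a fourth to come

A few compounds are considered here, and "the series" means these few. Any claim that something is new, unique, unknown or untested is made for them only; others in the source may bear on it.

Of the compounds shown here, three sharing one core have been measured in a functional assay on CHO cells for positive allosteric modulation of metabotropic glutamate receptor 2 (Homo sapiens), read by scintillation counting and GTPgammaS binding, with a stated time of 30 min; on this read-out lower numbers stand for smaller maximal responses and higher numbers for larger maximal responses. Compound 1 `CC(C)CCn1ccc(-c2ccc(OCC3CC3)cc2)c(C#N)c1=O` gives 192%, compound 2 `CC(C)CCn1ccc(-c2ccc(Oc3ccccn3)cc2)c(C#N)c1=O` gives 249%, and compound 3 `CC(C)CCn1ccc(-c2ccc(Oc3cccnc3)cc2)c(C#N)c1=O` gives 231%. Compound 3 thus stands second highest of the three: the step of a number 39 percentage points higher from compound 1 to compound 3 (beyond the scatter) is large, while the step of a number 18 percentage points lower from compound 2 to compound 3 (beyond the scatter) is modest, and both lie beyond the scatter.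

Compound 4 `Cc1cc(Oc2ccc(-c3ccn(CCC(C)C)c(=O)c3C#N)cc2)ccn1` has not yet been measured in this assay. It differs from compound 3 by 2-methylpyridin-4-yl in place of pyridin-3-yl on an oxygen on an aromatic ring. Only the pyridyl group on the oxygen changes; the rest of compound 3 is kept.

For the measured compounds named here, the steps that bear on this change are a number 57 percentage points higher from compound 1 to compound 2 (beyond the scatter) and a number 39 percentage points higher from compound 1 to compound 3 (beyond the scatter), which show that each pyridyl group on the oxygen gave a markedly larger maximal response than cyclopropylmethyl, and a number 18 percentage points lower from compound 2 to compound 3 (beyond the scatter), which shows that exchanging one pyridyl group for another moved the number only modestly. A third pyridyl group is therefore expected to leave compound 4 close to compounds 2 and 3, with no step beyond the scatter as the most likely outcome.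

Compound 4 is estimated to reach 235%, within a range from 200% to 270%. That estimate means an expected step of a number 4 percentage points higher from compound 3 to compound 4 (within the scatter).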

Compound 4, largest response reached (Emax), in percent of the reference or control that the assay uses: 266%
Compound 4: the middle estimate sits 31 percentage points below what was measured, within the range that was stated.
By their numbers in this assay, from the lowest: compound 1; then compound 3; then compound 2; then compound 4.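

In this assay, for the compounds shown here, the step of a number 35 percentage points higher from compound 3 to compound 4 (beyond the scatter) shows that exchanging one pyridyl group for another on this oxygen can produce a large change, whereas the only such exchange seen earlier, the step of a number 18 percentage points lower from compound 2 to compound 3 (beyond the scatter), was modest. The step of a number 17 percentage points higher from compound 2 to compound 4 (beyond the scatter) places 2-methylpyridin-4-yl above pyridin-2-yl as well, and the step of a number 74 percentage points higher from compound 1 to compound 4 (beyond the scatter) is the widest gap from cyclopropylmethyl among the three pyridyl ethers, so the earlier pyridyl groups did not mark the top of what this position can give. No measurement at hand explains this result.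

Compound 4 differs from compound 3 both in the methyl group and in the point at which the pyridine ring is joined to the oxygen, so the compounds shown cannot separate these two changes, and an unsubstituted pyridin-4-yl group would be needed to do so. They also leave open whether a plain phenyl ring, or an ethyl or methoxy group in place of the methyl, would hold the response on this oxygen at the level of compound 4.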